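Removing a Methyl from a Ring Oxygen of Compound 3

The source may hold more compounds than are shown below. What is called first, only, known or untested is meant among the compounds shown, and "the series" means these compounds.

Three compounds share one core and differ only in the groups on the outer ring. In a physicochemical assay, read by spectrophotometry, with a stated time of 30 min (a lower number here means a stronger inhibitor, a higher number a weaker inhibitor), compound 1 `COc1cc(/C=N/NC(=O)CCCc2nc3ccccc3c(=O)[nH]2)cc(O)c1O` gives 88000000 nM. Compound 2 `COc1cc(/C=N/NC(=O)CCc2nc3ccccc3c(=O)[nH]2)cc(OC)c1OC` gives 85000000 nM. Compound 3 `COc1cc(/C=N/NC(=O)CCc2nc3ccccc3c(=O)[nH]2)cc(OC)c1O` gives 126000000 nM, a number within the scatter of both others. The unmeasured compound 4 `COc1cc(/C=N/NC(=O)CCc2nc3ccccc3c(=O)[nH]2)cc(O)c1O` differs from compound 3 in one place: hydrogen in place of methyl on an oxygen on an aromatic ring. One measured step involves this same kind of change, a 1.5-fold higher number from compound 2 to compound 3 (0.17 log units; within the scatter), which lies within the scatter. Compound 1, which carries the same ring groups as compound 4, also sits within the scatter of compound 3. No step beyond the scatter is therefore expected. The expected step is a 1.2-fold lower number from compound 3 to compound 4 (0.08 log units; within the scatter). Compound 4 is estimated to give 105000000 nM, within a range from 50000000 nM to 220000000 nM.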

Compound 4, half-maximal inhibitory concentration: 104000000 nM
Beside the measured number, compound 4's estimate is 1.0-fold (0.00 log units) above it, and the stated range covers the measured number.
By their numbers in this assay, from the lowest: compounds 2, 1, 4 and 3 (each within the scatter of the next).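

Methoxy to hydroxy has now been read at a second oxygen on the aromatic ring: in this assay this change gives a 1.2-fold lower number from compound 3 to compound 4 (0.08 log units; within the scatter), much as the earlier swap gave a 1.5-fold higher number from compound 2 to compound 3 (0.17 log units; within the scatter) at another oxygen. At this oxygen, then, losing the methyl brings no change that the assay can tell apart from scatter. No measurement here explains this result.

The compounds shown leave open whether an ethyl on this oxygen, or an amine in place of the hydroxy, would move the number beyond the scatter.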